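A few compounds are considered here, and "the series" means these few. Any claim that something is new, unique, unknown or untested is made for them only; others in the source may bear on it.

Compound 1 `NC(=O)c1cccc(-c2ccc3oc(NC4CCCCC4)nc3c2)c1`: in an assay on HEK293 cells for inhibition of Fatty-acid amide hydrolase 1 (Homo sapiens), read by fluorescence (a higher number here means a weaker inhibitor, a lower number a stronger inhibitor), compound 1 gives only the assay limit > 1000 nM.
Compound 2 `Cn1ccc2cc(-c3ccc4oc(NC5CCCCC5)nc4c3)ccc21`: in this assay compound 2 gives 911 nM.
Compound 3 `NC(=O)Cn1ccc2cc(-c3ccc4oc(NC5CCCCC5)nc4c3)ccc21`: in this assay compound 3 gives 214 nM.

Compound 2 stands highest of the two numbers measured; the remaining value, that of compound 1, is a limit and not a number. The only step among these three that carries a number on both sides is a 4.3-fold lower number from compound 2 to compound 3 (0.63 log units; beyond the scatter), which changes the substituent on the saturated chain carbon bound to the aromatic nitrogen and leaves the other end of the shared core untouched.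

Compound 4 `Cn1ccc2cc(-c3ccc4oc(N5Cc6ccncc6C5)nc4c3)ccc21` differs from compound 2 at that other end: a group of 9 heavy atoms (7 carbon, 2 nitrogen; one five-membered non-aromatic ring with 1 hetero atom, one six-membered aromatic ring with 1 hetero atom) in place of a group of 7 heavy atoms (6 carbon, 1 nitrogen; one six-membered non-aromatic ring of carbon only), on an aromatic carbon.

No measured step touches this place on the core, so none of the steps shown bears on the change from compound 2 to compound 4. The hydrogen-bond donor of the cyclohexylamino group is lost and a second acceptor is gained, but nothing measured here tells what that does in this assay. The account therefore treats the change as open in direction and expects compound 4 to sit near compound 2, with a wide range: compound 4 is estimated at 700 nM, between 150 nM and 3000 nM, which is expected to amount to a 1.3-fold lower number from compound 2 to compound 4 (0.11 log units; within the scatter).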

Compound 4, half-maximal inhibitory concentration: 121 nM
The estimate for compound 4 lay 5.8-fold (0.76 log units) above the measured number, and the stated range ends above it.
By their numbers in this assay, from the lowest: compounds 4 and 3 (each within the scatter of the next); then compound 2. At a limit, above all of these: compound 1.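

For the compounds shown here, the place on the aromatic carbon of the five-membered aromatic ring, which no earlier step had touched, proves responsive in this assay: putting the group of 9 heavy atoms in place of cyclohexylamino gives a 7.5-fold lower number from compound 2 to compound 4 (0.88 log units; beyond the scatter). Going by these compounds alone, until now the only readable change lay at the other end of the shared core, with a 4.3-fold lower number from compound 2 to compound 3 (0.63 log units; beyond the scatter), and the new step adds a second change from compound 2 that lies beyond the scatter, this one with an entering group of 0 hydrogen-bond donors where cyclohexylamino has 1, so the donor of cyclohexylamino is not needed for the lower number in this pair. No measurement given here bears on why this replacement lowers the number.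

From the compounds shown here alone, what a morpholine or a piperidine would give at this place stays open, as does whether a benzene ring in place of the six-membered aromatic ring of the entering group would hold the number. Also open, going by these compounds, is whether the two steps add up when the carbamoyl group on the chain carbon and the entering group stand on one molecule.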